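The compounds below may be only part of what the source reports. "The series", "measured", "known", "first", "only" and "open" are said of these compounds alone.

Compound 1 `Cc1nn(-c2nc(-c3ccc(Cl)c(Cl)c3)c(SC(C)C)s2)c(C(=O)O)c1-c1ccc(Cl)cc1` gives 2500 nM in a functional assay on BJAB cells (Homo sapiens) for antiproliferative activity, with a stated time of 4 days (a higher number here means that more compound is needed for the effect, a lower number that less compound is needed), the higher of the two numbers in hand. Compound 2 `Cc1c(-c2cc(Cl)cc(Cl)c2)c(C(=O)O)nn1-c1nc(-c2cc(Cl)cc(Cl)c2)c(SC(C)C)s1` gives 2000 nM in this assay; the gap between compound 1 and compound 2 lies within the usual scatter, so the two stand level on this read-out. Compound 3 `Cc1nn(-c2nc(-c3ccc(Cl)c(Cl)c3)c(SC(C)C)s2)c(C(=O)O)c1-c1ccccc1Cl` has not yet been measured. It differs from compound 1 in one place: 2-chlorophenyl in place of 4-chlorophenyl on an aromatic carbon. Going by the values given here, no measured pair shows a change of this kind, so there is no anchor for the size of the step, and the two values at hand give no trend to lean on. The working expectation is therefore a step from compound 1 to compound 3 of modest size, at most a little beyond the scatter, more likely toward a higher number. Compound 3 is expected to give 3500 nM in this assay, within 1200 nM to 10000 nM. The expected step of a 1.4-fold higher number from compound 1 to compound 3 (0.15 log units; within the scatter) is small.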

Compound 3, half-maximal effective concentration: 13100 nM
For compound 3 the middle estimate is 3.7-fold (0.57 log units) below the measured one; the whole stated range lies below it.
By their numbers in this assay, from the lowest: compounds 2 and 1 (each within the scatter of the next); then compound 3.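

In this assay the chlorophenyl on the aromatic carbon next to the ring atom that bears a carboxy group proves sensitive to where its chlorine sits: 2-chlorophenyl in place of 4-chlorophenyl gives a 5.2-fold higher number from compound 1 to compound 3 (0.72 log units; beyond the scatter) even though the two compounds have the same atoms. Going by these compounds alone, this is the first one-place comparison, and it shows that a rearrangement of the same atoms at this position can move the number beyond the scatter, here toward more compound being needed. Nothing measured here speaks to the origin of this step.

Open, on these data alone, is whether a 2-fluorophenyl or 2-methoxyphenyl would give a step like that of 2-chlorophenyl, and whether an unsubstituted phenyl would stand nearer compound 1 or compound 3. Also open, as far as these compounds go, is whether the step would persist with an amide in place of the carboxy group.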